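The compounds below may be only part of what the source reports. "The series", "measured", "known", "first", "only" and "open" are said of these compounds alone.

In a functional assay on blood (Homo sapiens), with a stated time of 60 min, in the presence of a further agent that is not named here (on this read-out higher numbers stand for an effect only at larger amounts of compound and lower numbers for an effect already at smaller amounts), compound 1 `O=C(Oc1ccccc1)C1(S(=O)(=O)c2ccc(Oc3ccc(OC(F)(F)F)cc3)cc2)CCC2(CCNCC2)C1` gives 900 nM. Compound 2 `O=S(=O)(c1ccc(Oc2ccc(OC(F)(F)F)cc2)cc1)C1(CO)CCC2(CCNCC2)C1` gives > 15000 nM, and this is a limit of the assay, not a number. Compound 2 therefore has no exact position, and the step to it, with hydroxymethyl in place of phenoxycarbonyl on a saturated ring carbon, is an at least 16-fold higher number from compound 1 to compound 2 (1.22 log units; beyond the scatter).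

Compound 3 `NC(=O)C1(S(=O)(=O)c2ccc(Oc3ccc(OC(F)(F)F)cc3)cc2)CCC2(CCNCC2)C1` changes the same saturated ring carbon, with carbamoyl in place of hydroxymethyl on a saturated ring carbon. Within the data shown here, that large measured step is the only one bearing on this change, and it shows only that this ring carbon's substituent can matter in this assay. It involves a different incoming group, so it gives no direct measure for carbamoyl. A modest move towards a lower number is expected, but this move is not expected to reach compound 1, which gives 900 nM. The size of that move remains uncertain because of the limit of > 15000 nM in this assay, at which 1 of the 2 values shown sits. The expected change is an at least 1.6-fold lower number from compound 2 to compound 3 (0.22 log units; that floor lies within the scatter). For compound 3 the estimated value is 9000 nM, with an expected range from 2500 nM to 15000 nM.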

Compound 3, half-maximal effective concentration: 3700 nM
Compound 3: middle estimate off by 2.4-fold (0.39 log units), on the high side; low and high end bracket the measured number.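

In this assay, carbamoyl in place of hydroxymethyl on this saturated ring carbon gives an at least 4.0-fold lower number from compound 2 to compound 3 (0.60 log units; beyond the scatter), so the two groups can be told apart in this assay even though the size of the step has only a lower bound. Amino in place of phenoxy on the carbonyl carbon gives a 4.1-fold higher number from compound 1 to compound 3 (0.61 log units; beyond the scatter), which shows that a carbonyl on this ring carbon is not enough on its own to keep the number of compound 1 and that the group on the carbonyl carbon also matters. Compound 3 therefore lies between the other two compounds, and among these three groups the two that carry a carbonyl give exact numbers, while hydroxymethyl gives only a limit.

As far as these compounds go, how far compound 2 really lies from compound 3 stays open: the limit of > 15000 nM in this assay, at which 1 of the 3 values shown sits. It is also open whether a carboxylic acid, a methyl ester or an N-methyl amide on this ring carbon would stay near compound 3, at 3700 nM, or come closer to compound 1, at 900 nM.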